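Opening a ring into a hydroxypropyl chain

The compounds below may be only part of what the source reports. "The series", "measured", "known", "first", "only" and "open" are said of these compounds alone.

In an ADME assay on MT4 cells (Homo sapiens) for cytotoxicity, read by MTT assay, with a stated time of 5 days (on this read-out lower numbers stand for higher toxicity in this test and higher numbers for lower toxicity in this test), compound 1 `COc1cc2cc(C#N)ccc2c(OC)c1Oc1cc(NC2CCC2)nc(Nc2ccc(C#N)cc2)n1` gives > 125000 nM, which is a limit. Compound 2 `COc1cc2cc(C#N)ccc2c(OC)c1Oc1cc(NC2CCOC2)nc(Nc2ccc(C#N)cc2)n1` gives > 125000 nM, also only a limit. The measured evidence is the limit of > 125000 nM in this assay, at which 2 of the 2 values shown sit. Going by the values given here, the one measured step, a step that the two limits leave unreadable from compound 1 to compound 2, therefore has no readable size. Compound 3 `COc1cc2cc(C#N)ccc2c(OC)c1Oc1cc(NCCCO)nc(Nc2ccc(C#N)cc2)n1` differs from compound 2 as follows: 3-hydroxypropyl in place of oxolan-3-yl on a nitrogen on an aromatic ring. Among the compounds with values here, with no sized step to draw on, no change beyond the usual scatter is expected in this assay, and no direction can be foreseen. The expected step is a number no higher from compound 2 to compound 3 (the limit leaves the size open). The estimate for compound 3 is 125000 nM, with an expected range from 50000 nM to 250000 nM.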

Compound 3, half-maximal cytotoxic concentration: 23500 nM
Beside the measured number, compound 3's estimate is 5.3-fold (0.73 log units) above it; measured number outside the range, below it.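

In this assay, opening the ring gives an at least 5.3-fold lower number from compound 2 to compound 3 (0.72 log units; beyond the scatter), and the same chain in place of cyclobutyl gives an at least 5.3-fold lower number from compound 1 to compound 3 (0.72 log units; beyond the scatter). Going by these compounds alone, these are the first readable steps at this position, showing that the group on this nitrogen can shift the read-out towards higher toxicity in this test. Both are minimum sizes, and the true sizes stay hidden behind a limit: the limit of > 125000 nM in this assay, at which 2 of the 3 values shown sit.

Still open, as far as these compounds go, is whether the change follows from the chain's hydroxyl or from the loss of the ring. A plain propyl chain, a 3-methoxypropyl chain or a chain ending in an amine could help separate these possibilities.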